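Replacing tert-butyl with 3-fluorophenyl in the series

The compounds below may be only part of what the source reports. "The series", "measured", "known", "first", "only" and "open" are said of these compounds alone.

In an ADME assay on liver for metabolic stability, with Liver microsome (Homo sapiens) as the target, read by LC-MS, using microsomes (a higher number here means faster removal of the compound, a lower number slower removal), compound 1 `CC(C)(C)C[C@@H](O)C(=O)N1[C@@H]2C[C@@H]2C[C@H]1C(=O)NCc1cc(Cl)ccc1-n1cnnn1` gives 71 mL.min-1.g-1. Compound 2 `CC(C)(C)[C@@H](O)C(=O)N1[C@@H]2C[C@@H]2C[C@H]1C(=O)NCc1cc(Cl)ccc1-n1cnnn1` gives 54 mL.min-1.g-1, which places compound 2 level with compound 1 within the scatter. Compound 3 `O=C(NCc1cc(Cl)ccc1-n1cnnn1)[C@@H]1C[C@H]2C[C@H]2N1C(=O)[C@H](O)c1cccc(F)c1` has not yet been measured. The change to it is 3-fluorophenyl in place of tert-butyl on a saturated chain carbon bound to a carbonyl carbon and an oxygen on a saturated carbon.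

Among the compounds with values here, only one measured step bears on this place: tert-butyl in place of neopentyl, a 1.3-fold lower number from compound 1 to compound 2 (0.12 log units; within the scatter). Within the data shown here, that step swaps one saturated group for another, and no measured compound carries an aromatic ring at this place, so it is a weak guide. Among the measured compounds shown here, with compound 2 as the starting point and that small step as the only evidence, no step beyond the scatter is expected in this assay, and either direction remains open. The expected step is a 1.2-fold lower number from compound 2 to compound 3 (0.08 log units; within the scatter). For compound 3 the estimate is 45 mL.min-1.g-1, with an expected range of 20 mL.min-1.g-1 to 100 mL.min-1.g-1.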

Compound 3, intrinsic clearance in microsomes: 32 mL.min-1.g-1
Compound 3: the middle estimate sits 1.4-fold (0.15 log units) above what was measured; the measured number falls inside the stated range.
By their numbers in this assay, from the lowest: compounds 3, 2 and 1 (each within the scatter of the next, the first and the last beyond it).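

In this assay this place on the saturated chain carbon accepts an aromatic ring without a step beyond the scatter from tert-butyl, the step being a 1.7-fold lower number from compound 2 to compound 3 (0.23 log units; within the scatter) and 3-fluorophenyl therefore not being separable from tert-butyl in these notes. Set against neopentyl, the same ring gives the first step at this place that clears the scatter, a 2.2-fold lower number from compound 1 to compound 3 (0.35 log units; beyond the scatter) and modest in size, so the earlier saturated pair alone did not show that a change here could be read at all, and among these three compounds only this pair is separated. Nothing at hand explains why this change gives that step, so the result stands as an observation on the numbers alone.

With one aromatic group at this place, the shares of the ring and of its fluorine cannot be told apart, and a plain phenyl would be needed to divide them. Whether the trend to a lower number would hold for a pyridine ring, an amine or a carboxylic acid at this place stays open, since none of these groups appears among the compounds shown.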